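Chloro to fluoro on the aryl ring of the series

The source may hold more compounds than are shown below. What is called first, only, known or untested is meant among the compounds shown, and "the series" means these compounds.

Measured in a functional assay on the whole organism (strain Albino Wistar) for inhibition, with Rattus norvegicus as the target, read by paw edema, with stated times of 1 h and 3 h, at a dose of 10 mg/kg by the oral route; a lower number here means less inhibition, a higher number more inhibition at the dose given (going by the name of the read-out):
compound 1 `Clc1ccccc1-n1cc(CSc2nc3ccccc3s2)nn1`: 83.3%
compound 2 `Clc1cccc(-n2cc(CSc3nc4ccccc4s3)nn2)c1`: 35%
compound 3 `Clc1ccc(-n2cc(CSc3nc4ccccc4s3)nn2)cc1`: 50%

Compound 3 stands second highest of the three, below compound 1 by a number 33.3 percentage points lower from compound 1 to compound 3 (beyond the scatter) and above compound 2 by a number 15 percentage points higher from compound 2 to compound 3 (beyond the scatter); both gaps lie beyond the scatter. Compound 4 `Fc1ccc(-n2cc(CSc3nc4ccccc4s3)nn2)cc1` differs from compound 3 by fluoro in place of chloro on an aromatic carbon. Going by the values given here, none of the measured steps probes a change of halogen; all three move chloro around the ring, and compound 1 to compound 2 gives a number 48.3 percentage points lower from compound 1 to compound 2 (beyond the scatter). The data therefore carry no direct guide for the swap, and with the group kept at the same place a step within the scatter is expected, written as a number 2 percentage points lower from compound 3 to compound 4 (within the scatter). Compound 4 is estimated at 48% in this assay, with an expected range from 30% to 65%.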

Compound 4, a percentage reported as inhibition, in the whole organism at one dose (the size of the read-out at that dose, not a potency): 77.8%
Compound 4: the middle estimate sits 29.8 percentage points below what was measured; measured number above the stated range.
By their numbers in this assay, from the lowest: compound 2; then compound 3; then compounds 4 and 1 (each within the scatter of the next).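

In this assay the halogen itself counts at this place, not only its position on the ring: with the position held, 4-fluorophenyl in place of 4-chlorophenyl gives a number 27.8 percentage points higher from compound 3 to compound 4 (beyond the scatter) and so changes the read-out beyond the scatter. Compound 4 also stands clear of the 3-chlorophenyl analogue, with a number 42.8 percentage points higher from compound 2 to compound 4 (beyond the scatter) and, at a number 5.5 percentage points lower from compound 1 to compound 4 (within the scatter) against the 2-chlorophenyl analogue, shows that a high read-out in this small set does not belong to the 2-chlorophenyl group alone. Nothing at hand accounts for the size of the gain from chloro to fluoro.

Open, from the compounds shown here alone, is whether the 2-chlorophenyl and 3-chlorophenyl compounds would respond to the same swap of halogen. Also open, going by these compounds, is whether methoxy, an amine or a carboxylic acid in the place of the fluoro would keep the read-out of compound 4.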